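Sulfone and thioether analogues: a halogen-for-methoxy swap

A few compounds are considered here, and "the series" means these few. Any claim that something is new, unique, unknown or untested is made for them only; others in the source may bear on it.

The series is measured in a functional assay on DU-145 cells (Homo sapiens) for inhibition, read by trypan blue exclusion, with a stated time of 96 h; a higher number here means a weaker inhibitor of growth, a lower number a stronger inhibitor of growth. Compound 1 `O=C(/C(=C\c1ccc(Cl)cc1)S(=O)(=O)c1ccc(Br)cc1)c1ccc(Br)cc1` gives 50000 nM there. Compound 2 `COc1ccc(/C=C(\C(=O)c2ccc(Br)cc2)S(=O)(=O)c2ccc(Br)cc2)cc1` carries a methoxy in place of the chloro of compound 1; in this assay compound 2 gives 25000 nM. Going the other way, the step of a 2.0-fold higher number from compound 2 to compound 1 (0.30 log units; within the scatter) is one the assay cannot tell apart from noise. Compound 3 `COc1ccc(/C=C(/SCc2ccc(Cl)cc2)C(=O)c2ccc(Br)cc2)cc1` gives 10000 nM in this assay, the lowest number of the three; the difference between its core and that of compound 2 is not broken down here, so nothing is said about how much of that gap belongs to the core.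

Compound 4 `O=C(/C(=C\c1ccc(Cl)cc1)SCc1ccc(Cl)cc1)c1ccc(Br)cc1` has not been measured. It differs from compound 3 by chloro in place of methoxy on an aromatic carbon. This is the same change as that from compound 2 to compound 1, (chloro in place of methoxy on an aromatic carbon), made at the same kind of place, para to a large group on a six-membered aromatic ring of carbon only; it occurs twice among these compounds.

Among the measured compounds shown here, the only measured instance of the change is within the scatter, so the step from compound 3 to compound 4 is expected to be small as well, estimated at a 2.0-fold higher number from compound 3 to compound 4 (0.30 log units; within the scatter), resting on the step from compound 2 to compound 1. Compound 4 is therefore estimated at 20000 nM in this assay, with a likely range from 8000 nM to 50000 nM.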

Compound 4, concentration for 50% growth inhibition: 10000 nM
For compound 4 the middle estimate is 2.0-fold (0.30 log units) above the measured one, and the stated range covers the measured number.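

On the second core, the change from 4-methoxyphenyl to 4-chlorophenyl gives, in this assay, no change at the digits printed from compound 3 to compound 4 (within the scatter). Set beside the earlier instance, the change reads alike on both cores, and the gap between the two steps is no larger than the assay can resolve: the same change on two cores in this assay, a 2.0-fold higher number (0.30 log units; within the scatter) from compound 2 to compound 1 and no change at the digits printed (within the scatter) from compound 3 to compound 4, 2.0-fold (0.30 log units) apart, within the scatter of two such steps This shows that, for these two cores, neither step can be told from noise and nothing marks the change as dependent on the core, but it does not show that the two steps are truly equal, nor that the change would stay this small on any core beyond these two, as only two pairs of compounds stand behind the comparison.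

The compounds shown leave open whether a different group at the same place, such as an amine, a carboxylic acid, a hydroxy or a longer alkoxy chain, would give a step beyond the scatter on either core. They also leave open whether the same exchange of methoxy and chloro, made on another aromatic ring of these molecules, would read the same way in this assay.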